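A few compounds are considered here, and "the series" means these few. Any claim that something is new, unique, unknown or untested is made for them only; others in the source may bear on it.

Values so far in a functional assay on PANC-1 cells (Homo sapiens) for cytotoxicity, with a stated time of 7 days; on this read-out lower numbers stand for stronger inhibition and higher numbers for weaker inhibition:
- compound 1 `CNC(=O)c1ccccc1SC/C=C(\C)CC/C=C(\C)CCC=C(C)C` gives 10000 nM
- compound 2 `COC(=O)c1ccccc1SC/C=C(\C)CC/C=C(\C)CCC=C(C)C` gives 30000 nM
- compound 3 `CC(C)=CCC/C(C)=C/CC/C(C)=C/CSc1ccccc1C(=O)OCc1ccccc1` gives 95000 nM

Compound 2 holds the middle of these three numbers, above compound 1 and below compound 3. The unmeasured compound 4 `CC(C)=CCC/C(C)=C/CC/C(C)=C/CSc1ccccc1C(N)=O` carries amino in place of methoxy on a carbonyl carbon so methoxycarbonyl becomes carbamoyl. The closest measured change is a 3.0-fold higher number from compound 1 to compound 2 (0.48 log units; beyond the scatter) when methoxy replaces methylamino, and a 9.5-fold higher number from compound 1 to compound 3 (0.98 log units; beyond the scatter) with benzyloxy points the same way. Both steps are modest and beyond the scatter. Read in reverse, they favour a lower number when a nitrogen group returns, though no measured compound carries amino itself. The expected step is therefore modest and downward (a 2.5-fold lower number from compound 2 to compound 4 (0.40 log units; beyond the scatter)). Compound 4 is estimated at 12000 nM with an expected range from 4000 nM to 35000 nM in this assay once measured.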

Compound 4, half-maximal inhibitory concentration: 20000 nM
Compound 4: the middle estimate sits 1.7-fold (0.22 log units) below what was measured; the range from low to high includes it.
By their numbers in this assay, from the lowest: compounds 1, 4 and 2 (each within the scatter of the next, the first and the last beyond it); then compound 3.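

Within this assay, amino in place of methoxy on this carbonyl carbon gives a 1.5-fold lower number from compound 2 to compound 4 (0.18 log units; within the scatter) and so does not separate the two groups, which means that a nitrogen here does not by itself bring a clear change. Hydrogen in place of methyl on the amide-type nitrogen gives a 2.0-fold higher number from compound 1 to compound 4 (0.30 log units; within the scatter) and also stays inside the scatter, whereas amino in place of benzyloxy gives a 4.8-fold lower number from compound 3 to compound 4 (0.68 log units; beyond the scatter) and clearly stands apart. No supporting measurement bears on these steps. Still open, on these data alone, is how hydroxy, which would make a carboxylic acid, or dimethylamino would compare on this carbonyl carbon.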